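The source may hold more compounds than are shown below. What is called first, only, known or untested is meant among the compounds shown, and "the series" means these compounds.

Compound 3 `CCC(CC)c1ccc2c(NCCCNCc3ccco3)ccnc2c1` gives 23 10^-6 cm/s in an ADME assay for permeability, using PAMPA, with a stated time of 30 min, at pH 7.4 (on this read-out higher numbers stand for higher permeability and lower numbers for lower permeability), level with compound 1 `Cc1cc(C)cc(Cc2ccc3c(NCCCNCc4ccco4)ccnc3c2)c1` at 23 10^-6 cm/s and together with it the lowest of the three numbers; compound 2 `CC(C)(C)c1ccc(-c2ccc3c(NCCCNCc4ccco4)ccnc3c2)cc1` stands furthest away at 237 10^-6 cm/s. Compound 4 `COc1ccc(Oc2ccc3c(NCCCNCc4ccco4)ccnc3c2)cc1` is not yet measured; the change from compound 3 is 4-methoxyphenoxy in place of pentan-3-yl on an aromatic carbon. The step of a 10-fold lower number from compound 2 to compound 3 (1.01 log units; beyond the scatter) is the one that bears directly, since it also exchanges an aryl group for pentan-3-yl; a 10-fold higher number from compound 1 to compound 2 (1.01 log units; beyond the scatter) and no change at the digits printed from compound 1 to compound 3 (within the scatter) frame the same pair. Within the data shown here, a rise is therefore expected for compound 4 because a 10-fold lower number from compound 2 to compound 3 (1.01 log units; beyond the scatter) ran the other way, though the entering group carries two acceptors that none of the measured compounds has, so the step of a 3.0-fold higher number from compound 3 to compound 4 (0.48 log units; beyond the scatter) is estimated smaller. Compound 4 is expected at 70 10^-6 cm/s, within 23 10^-6 cm/s to 210 10^-6 cm/s.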

Compound 4, apparent permeability: 317 10^-6 cm/s
Compound 4: the middle estimate sits 4.5-fold (0.66 log units) below what was measured; measured number outside the range, above it.
By their numbers in this assay, from the lowest: compounds 1 and 3 (each within the scatter of the next); then compounds 2 and 4 (each within the scatter of the next).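

At this aromatic carbon in this assay, 4-methoxyphenoxy stands well clear of pentan-3-yl (a 14-fold higher number from compound 3 to compound 4 (1.14 log units; beyond the scatter)) and of 3,5-dimethylbenzyl (a 14-fold higher number from compound 1 to compound 4 (1.14 log units; beyond the scatter)). Against 4-(tert-butyl)phenyl the step stays within the scatter (a 1.3-fold higher number from compound 2 to compound 4 (0.13 log units; within the scatter)), so the high level is not tied to one group and is reached by one carrying hydrogen-bond acceptors. Compounds 2 and 4 both carry a further aromatic ring here, but compound 1 goes against any rule based on that ring. As far as these compounds go, how a piperidine or a carboxylic acid at this carbon would read remains open. Nothing available accounts for these steps.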